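The source may report more compounds than this note shows. Statements on the series, on what has been measured and on what is new or still open speak of the compounds shown alone.

Measured in an ADME assay on RAW264.7 cells (Mus musculus) for cytotoxicity, read by MTT assay, with a stated time of 48 h; on this read-out lower numbers stand for higher toxicity in this test and higher numbers for lower toxicity in this test:
compound 1 `CC(=O)OC[C@H]1O[C@H](OC[C@H](Cn2cc(COc3ccc(-c4noc(NC5CCCCC5)n4)cc3)nn2)OC(C)=O)C=C[C@@H]1OC(C)=O` gives 33.3 ug/mL.
compound 2 `CC(=O)OC[C@H]1O[C@H](OC[C@@H](Cn2cc(CN(c3nc(-c4ccc(Cl)cc4)no3)C3CCCCC3)nn2)OC(C)=O)C=C[C@@H]1OC(C)=O` gives 35.5 ug/mL.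
compound 3 `CC(=O)OC[C@H]1O[C@H](OC[C@@H](Cn2cc(CN(c3nc(-c4ccc(F)cc4)no3)C3CCCCC3)nn2)OC(C)=O)C=C[C@@H]1OC(C)=O` gives 31.5 ug/mL.

Compound 3 has the lowest of the three numbers, but its gaps to compound 1 and to compound 2 both lie within the scatter, so the three compounds cannot be told apart in this assay. The step to compound 4 `CC(=O)OC[C@H]1O[C@H](OC[C@@H](Cn2cc(CN(c3nc(-c4ccc(Br)cc4)no3)C3CCCCC3)nn2)OC(C)=O)C=C[C@@H]1OC(C)=O` is bromo in place of fluoro on an aromatic carbon. Among the compounds with values here, the only measured step on this aromatic carbon, a 1.1-fold lower number from compound 2 to compound 3 (0.05 log units; within the scatter), was within the scatter, and the exchange of one halogen for another there has so far not moved the read-out. A step of a 1.0-fold higher number from compound 3 to compound 4 (0.02 log units; within the scatter) is therefore expected, none beyond the scatter. Compound 4 is estimated at 33 ug/mL, with a range of 20 ug/mL to 55 ug/mL.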

Compound 4, half-maximal cytotoxic concentration: 39.1 ug/mL
For compound 4 the middle estimate is 1.2-fold (0.07 log units) below the measured one, within the range that was stated.
By their numbers in this assay, from the lowest: compounds 3, 1, 2 and 4 (each within the scatter of the next).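

In this assay bromo in place of fluoro gives a 1.2-fold higher number from compound 3 to compound 4 (0.09 log units; within the scatter) and bromo in place of chloro gives a 1.1-fold higher number from compound 2 to compound 4 (0.04 log units; within the scatter) and so the flat response on this aromatic carbon, earlier seen only for the exchange of chloro and fluoro, now spans fluoro, chloro and bromo in compounds 2, 3 and 4. Nothing at hand explains this flat response. On these data alone, whether a group other than a halogen here, such as an amine, a methoxy group or a carboxylic acid, would move the read-out stays open. As far as these compounds go, compounds 2, 3 and 4 share one core, so it also stays open whether this holds on another core.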